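Removing the fluoro from compound 2: an estimate for compound 3

The source may report more compounds than this note shows. Statements on the series, on what has been measured and on what is new or still open speak of the compounds shown alone.

Compound 1, `O=Cc1c(-c2ccc(F)cc2)nc2sc(Cc3ccc(Cl)cc3)nn12`, gives 20000 nM in a functional assay on L1210 cells (Mus musculus) for cytotoxicity, with a stated time of 48 h; a lower number here means a stronger inhibitor, a higher number a weaker inhibitor. Compound 2, `N#CSc1c(-c2ccc(F)cc2)nc2sc(Cc3ccc(Cl)cc3)nn12`, gives 23000 nM.

Only these two numbers are known, and compound 2 lies within the scatter of compound 1: the step of a 1.2-fold higher number from compound 1 to compound 2 (0.06 log units; within the scatter). That step swaps the group on one aromatic carbon of the shared core and says nothing about the other end of the molecule.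

Compound 3, `N#CSc1c(-c2ccccc2)nc2sc(Cc3ccc(Cl)cc3)nn12`, differs from compound 2 in exactly that other end: hydrogen in place of fluoro on an aromatic carbon. Among the compounds with values here, no measured step touches this place, so there is nothing in the data that points up or down for it. Within the data shown here, the one step that was measured left the number essentially unchanged, and the change to compound 3 is a small one, a single heavy atom leaving. The expectation is therefore a step of a 1.0-fold higher number from compound 2 to compound 3 (0.02 log units; within the scatter) in this assay, that is, none beyond the scatter. Compound 3 is expected to give about 24000 nM, with a plausible range from 10000 nM to 55000 nM.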

Compound 3, half-maximal inhibitory concentration: 24000 nM
The estimate for compound 3 equals the measured number at the digits printed, and the stated range covers the measured number.
By their numbers in this assay, from the lowest: compounds 1, 2 and 3 (each within the scatter of the next).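

In this assay the swap of 4-fluorophenyl to phenyl comes out as a 1.0-fold higher number from compound 2 to compound 3 (0.02 log units; within the scatter) and so gives two numbers that cannot be told apart. Within the data shown here, this is the first measured step at this end of the molecule, on an aromatic carbon para to a large group, whereas the earlier step concerned only the group on the shared core. With the cyanosulfanyl group in place, the fluoro therefore makes no difference that this read-out can detect, though nothing measured here offers an explanation for that result.

The compounds shown carry only fluoro or hydrogen at this place, so it remains open whether a larger or very different group there, such as methoxy, an amine or a carboxylic acid, would give a number beyond the scatter. On these data alone, it is also open whether removing the fluoro would give the same result with formyl on the core, as this step has been read only with cyanosulfanyl.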